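The compounds below may be only part of what the source reports. "The series", "measured", "known", "first", "only" and "open" are said of these compounds alone.

Measured so far:
compound 1, `COc1ccc2[nH]c(C(=O)N3CC(=O)N(Cc4ccccc4)[C@@H](COc4ccccc4)C3)cc2c1`: 12200 nM
compound 2, `COc1ccc2[nH]c(C(=O)N3CC(=O)N(Cc4ccccc4)[C@@H](COC(C)(C)C)C3)cc2c1`: 65500 nM

Going by the values given here, in a physicochemical assay for solubility, read by spectrophotometry, in phosphate buffer, with a stated time of 2 h, at pH 7.4 (on this read-out higher numbers stand for higher solubility and lower numbers for lower solubility), compound 2 stands highest of the two numbers, with compound 1 as its only neighbour. Among the compounds with values here, the single measured step, a 5.4-fold higher number from compound 1 to compound 2 (0.73 log units; beyond the scatter), rests on a tert-butyl in place of phenyl on an oxygen on a saturated carbon, and it shows that a change at this position can move the read-out beyond the scatter.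

Compound 3, `COc1ccc2[nH]c(C(=O)N3CC(=O)N(Cc4ccccc4)[C@@H](CN4CCN(c5ccccn5)CC4)C3)cc2c1`, differs from compound 2 by 4-(pyridin-2-yl)piperazin-1-yl in place of tert-butoxy on a saturated chain carbon bound to a saturated ring carbon. Within the data shown here, no measured step covers this kind of exchange; the one step known concerns the same position but a different pair of groups, so it bears on the estimate only loosely. He therefore expects a step no larger than modest, more likely upward than downward, with a wide range. Compound 3 is expected at 100000 nM, between 25000 nM and 400000 nM. This corresponds to an expected step of a 1.5-fold higher number from compound 2 to compound 3 (0.18 log units; within the scatter).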

Compound 3, solubility: 30200 nM
The estimate for compound 3 lay 3.3-fold (0.52 log units) above the measured number; low and high end bracket the measured number.
By their numbers in this assay, from the lowest: compound 1; then compound 3; then compound 2.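

In this assay, going by these compounds alone, the earlier compounds showed only that this position on a saturated chain carbon bound to a saturated ring carbon can move the read-out. The new compound shows that one entering group can move it either way: 4-(pyridin-2-yl)piperazin-1-yl in place of tert-butoxy gives a 2.2-fold lower number from compound 2 to compound 3 (0.34 log units; beyond the scatter) and in place of phenoxy gives a 2.5-fold higher number from compound 1 to compound 3 (0.39 log units; beyond the scatter) on the same read-out. The direction of this change therefore depends on the group that leaves, and no measurement at hand accounts for either step.

The compounds shown leave open how much of this belongs to the piperazine ring and how much to its pyridin-2-yl. A simple amine such as dimethylamino on the same chain carbon would bear on that question.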